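The source may hold more compounds than are shown below. What is called first, only, known or untested is meant among the compounds shown, and "the series" means these compounds.

Measured in a functional assay on UACC-62 cells (Homo sapiens) for cytotoxicity, read by MTT assay, with a stated time of 6 days; on this read-out lower numbers stand for stronger inhibition and higher numbers for weaker inhibition:
- compound 1 `COc1ccccc1NC(=O)SC[C@H](NC(C)=O)C(=O)O`: > 200000 nM (a limit)
- compound 2 `CC(=O)N[C@@H](CSC(=O)Nc1ccccc1F)C(=O)O`: > 200000 nM (a limit)
- compound 3 `CC(=O)N[C@@H](CSC(=O)Nc1ccccc1Cl)C(=O)O`: > 200000 nM (a limit)

Compound 1 stands at > 200000 nM, which is a limit of the assay and not a number. Compound 2 and compound 3 also give only limits, so the series has no measured number yet.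

The next compound is compound 4 `COc1ccc(OC)c(NC(=O)SC[C@H](NC(C)=O)C(=O)O)c1`, which differs from compound 1 by methoxy in place of hydrogen on an aromatic carbon.

Only the three steps among the measured compounds can bear on this change: a step that the two limits leave unreadable from compound 1 to compound 2, a step that the two limits leave unreadable from compound 1 to compound 3 and a step that the two limits leave unreadable from compound 2 to compound 3. All of them exchange a group on an aromatic carbon, but none adds a second methoxy, and none has a readable size. For the measured compounds named here, the only guide is the limit of > 200000 nM in this assay, at which 3 of the 3 values shown sit. On that basis, no step beyond the usual scatter is expected in this assay, and neither direction is favoured. The assay may well report only a limit again.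

The expected change is a number no higher from compound 1 to compound 4 (the limit leaves the size open). For compound 4 the estimated value is 200000 nM, with an expected range from 80000 nM to 300000 nM.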

Compound 4, half-maximal inhibitory concentration: > 200000 nM
Compound 4 was reported as a limit; the forecaster's own chance of this, stated with the estimate: 80%; the middle value lies on the limit itself.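

In this assay compound 4 gives > 200000 nM, which is a limit and not a number. Compound 1 also gives only a limit, so the step between compound 1 and compound 4 cannot be read: the limit of > 200000 nM in this assay, at which 4 of the 4 values shown sit.

The compounds shown leave open whether any change to the shared core would give a readable value in this assay.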